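A Larger Ring Group on the Aromatic Nitrogen

This account rests on a few compounds, and the source may have more. Where it says the series, first, only, none or still open, it means among the compounds named here.

Compound 1 `CCn1nc(C(=O)N[C@H]2COc3ccccc3N(C)C2=S)nc1Cc1ccccc1` gives 17 nM in a functional assay on HT-29 cells (Homo sapiens) for inhibition, read by luminescence and CellTiter-Glo, with a stated time of 24 h (on this read-out higher numbers stand for an effect only at larger amounts of compound and lower numbers for an effect already at smaller amounts), the lowest number among the three measured compounds. Compound 2 `CCCCCn1nc(C(=O)N[C@H]2COc3ccccc3N(C)C2=S)nc1Cc1ccccc1` gives 805 nM, and compound 3 `CN1C(=S)[C@@H](NC(=O)c2nc(Cc3ccccc3)n(C3CCCCCC3)n2)COc2ccccc21` gives 5530 nM. Both carry a larger group than ethyl on the same aromatic nitrogen, and both steps were large: a 47-fold higher number from compound 1 to compound 2 (1.68 log units; beyond the scatter) and a 330-fold higher number from compound 1 to compound 3 (2.51 log units; beyond the scatter). Compound 4 `CN1C(=S)[C@@H](NC(=O)c2nc(Cc3ccccc3)n(C3CCOCC3)n2)COc2ccccc21` makes a related change, (oxan-4-yl in place of ethyl on an aromatic nitrogen). The entering oxan-4-yl is a six-membered non-aromatic ring, and every measured enlargement of the group on this nitrogen raised the number sharply, so a large rise is expected for compound 4 in this assay. Compound 4 is therefore estimated at 1500 nM, with a range from 300 nM to 8000 nM, an expected step of an 88-fold higher number from compound 1 to compound 4 (1.95 log units; beyond the scatter).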

Compound 4, half-maximal effective concentration: 2260 nM
The estimate for compound 4 lay 1.5-fold (0.18 log units) below the measured number; the measured number falls inside the stated range.
By their numbers in this assay, from the lowest: compound 1; then compound 2; then compound 4; then compound 3.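

The oxan-4-yl ring brings an oxygen into the group, yet the number stays far from that of the ethyl compound (a 130-fold higher number from compound 1 to compound 4 (2.12 log units; beyond the scatter)) in this assay. Oxan-4-yl instead falls among the other large groups, with modest steps from cycloheptyl (a 2.4-fold lower number from compound 3 to compound 4 (0.39 log units; beyond the scatter)) and from pentyl (a 2.8-fold higher number from compound 2 to compound 4 (0.45 log units; beyond the scatter)), so the oxygen-bearing ring does not recover the low number of compound 1. Nothing available explains these differences.

As far as these compounds go, whether methyl, a group smaller than ethyl, would give a lower number remains open. So does whether a ring carrying an amine, such as piperidin-4-yl, would behave like oxan-4-yl.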